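A few compounds are considered here, and "the series" means these few. Any claim that something is new, unique, unknown or untested is made for them only; others in the source may bear on it.

Notes on the series. Compound 1 `N=C(NO)N/N=C/c1ccccc1Cl` has been run in an ADME assay on Vero cells (Chlorocebus sabaeus) for cytotoxicity; a lower number here means that less compound is tolerated, a higher number that more compound is tolerated. In this assay compound 1 gives only a limit, > 100000 nM. Compound 2 `N=C(NO)N/N=C/c1ccc(Cl)cc1` also gives only a limit in this assay, > 100000 nM. Compound 3 `Cc1ccc(/C=N/NC(=N)NO)cc1` likewise returns a limit in this assay, > 100000 nM. Going by the values given here, compound 3 therefore stands on a limit alone, and the two further values shown are limits as well, so the single step between measured neighbours, a step that the two limits leave unreadable from compound 2 to compound 3, cannot be read for size or direction. All three values share (the limit of > 100000 nM in this assay, at which 3 of the 3 values shown sit).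

Compound 4 `N=C(NO)N/N=C/c1ccccc1` has not yet been measured in this assay. It differs from compound 3 in one place: hydrogen in place of methyl on an aromatic carbon. Among the compounds with values here, no measured step bears on this change with a readable size, since the one step on record, a step that the two limits leave unreadable from compound 2 to compound 3, ends in a limit on both sides. Within the data shown here, nothing measured so far points to a step beyond the scatter in this assay. Compound 4 is therefore expected to sit at the limit as well, estimated at 150000 nM with a range of 70000 nM to 400000 nM. The step this estimate implies, a step that the limit leaves unreadable from compound 3 to compound 4, is expected to be none beyond the scatter.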

Compound 4, half-maximal cytotoxic concentration: > 100000 nM
Compound 4 gave a limit, no number; the forecaster's own chance of this, stated with the estimate: 85%; the middle value lies beyond the limit too.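

The steps from compound 1, compound 2 and compound 3 to compound 4 cannot be read for size or direction, because every value is only a limit: the limit of > 100000 nM in this assay, at which 4 of the 4 values shown sit.

The compounds shown leave open how far any of the four lies past that limit in this assay.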